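A Methoxy Group Enters the Anilino Ring of Compound 2

The source may report more compounds than this note shows. Statements on the series, on what has been measured and on what is new or still open speak of the compounds shown alone.

Compound 1 `CC(C)Nc1nc(/C=C/c2ccccc2)nc2ccsc12`: > 1000000 nM
Compound 2 `C(=C/c1nc(Nc2ccccc2)c2sccc2n1)\c1ccccc1`: > 1000000 nM
Compound 3 `CN(c1ccccc1)c1nc(/C=C/c2ccccc2)nc2ccsc12`: > 1000000 nM

Three compounds share one core and differ only in the amine attached to it. In a functional assay on L02 cells (Homo sapiens) for inhibition, read by Griess assay, with stated times of 1 h and 24 h (a higher number here means a weaker inhibitor, a lower number a stronger inhibitor), compound 1 gives > 1000000 nM, which is a limit of the assay rather than a number. Compound 2 gives > 1000000 nM, also a limit. Compound 3 gives > 1000000 nM, a limit as well. All three values rest at the limit of > 1000000 nM in this assay, at which 3 of the 3 values shown sit. Compound 2 therefore stands at the limit, with no measured number of its own.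

Every value is a limit. Among the measured compounds shown here, none of the measured steps can be read: a step that the two limits leave unreadable from compound 1 to compound 2, a step that the two limits leave unreadable from compound 1 to compound 3 and a step that the two limits leave unreadable from compound 2 to compound 3 all remain of unknown size. None of them touches the phenyl ring itself.

Compound 4 `COc1ccc(Nc2nc(/C=C/c3ccccc3)nc3ccsc23)cc1` differs from compound 2 by methoxy in place of hydrogen on an aromatic carbon. The measured steps bear on this change only in that they show the anilino series as a whole at the limit; they give no direction. In this assay the expected step of a number no higher from compound 2 to compound 4 (the limit leaves the size open) is therefore none beyond the scatter. Compound 4 is estimated at 1000000 nM, with a range from 100000 nM to 3000000 nM, most likely reported again as a limit.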

Compound 4, half-maximal inhibitory concentration: > 1000000 nM
Compound 4 gave a limit, no number; the forecaster's own chance of this, stated with the estimate: 80%; the middle value sits exactly at the limit.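

In this assay compound 4 gives > 1000000 nM, a limit of the assay and not a number. The new steps to compound 4 from compound 1 and compound 2 therefore cannot be read: the limit of > 1000000 nM in this assay, at which 4 of the 4 values shown sit.

The compounds shown leave open whether any amine on the shared core, with or without methoxy, gives a measurable value in this assay.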